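This account rests on a few compounds, and the source may have more. Where it says the series, first, only, none or still open, it means among the compounds named here.

In a functional assay on SGC-7901 cells (Homo sapiens) for cytotoxicity, read by MTT assay, with a stated time of 48 h (a higher number here means a weaker inhibitor, a lower number a stronger inhibitor), compound 1 `Cc1ncc([N+](=O)[O-])n1CCSc1nnc(-c2ccccc2)o1` gives 30100 nM as its value. Compound 2 `Cc1ccc(-c2nnc(SCCn3c([N+](=O)[O-])cnc3C)o2)cc1` gives 12500 nM as its value, and compound 3 `Cc1ncc([N+](=O)[O-])n1CCSc1nnc(-c2ccc(F)cc2)o1` holds the lowest number of the three with 5300 nM as its value. Compound 4 `Cc1ccc(-c2nnc(SCCn3c([N+](=O)[O-])cnc3C)o2)c(O)c1` is not yet measured. It carries 2-hydroxy-4-methylphenyl in place of 4-fluorophenyl on an aromatic carbon, with 2-hydroxy-4-methylphenyl in place of 4-fluorophenyl on an aromatic carbon as the difference from compound 3.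

The closest guide is a 2.4-fold lower number from compound 2 to compound 3 (0.37 log units; beyond the scatter) for fluoro in place of methyl, read in reverse, since compound 4 has a methyl on its phenyl ring as compound 2 does. Also modest are a 2.4-fold lower number from compound 1 to compound 2 (0.38 log units; beyond the scatter) for methyl in place of hydrogen and a 5.7-fold lower number from compound 1 to compound 3 (0.75 log units; beyond the scatter) for fluoro in place of hydrogen. Among the measured compounds shown here, no measured compound carries a hydroxy group, so that part of the change has no measured step and the uncertainty is wide.

A modest move to a higher number is therefore expected in this assay for this change. The expected step is a 2.1-fold higher number from compound 3 to compound 4 (0.32 log units; beyond the scatter) on this estimate. For compound 4 the estimated value is 11000 nM with an expected range from 3500 nM to 30000 nM in all.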

Compound 4, half-maximal inhibitory concentration: 36700 nM
Estimate against measurement, compound 4: 3.3-fold (0.52 log units) below; the measured number lies above the stated range.
By their numbers in this assay, from the lowest: compound 3; then compound 2; then compounds 1 and 4 (each within the scatter of the next).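

In this assay, among the compounds shown here, hydroxy in place of hydrogen is the first change on this aromatic ring to give a higher number, a 2.9-fold higher number from compound 2 to compound 4 (0.47 log units; beyond the scatter), whereas the methyl and fluoro steps from the phenyl of compound 1 both gave lower numbers. With 2-hydroxy-4-methylphenyl in place of 4-fluorophenyl the result is a 6.9-fold higher number from compound 3 to compound 4 (0.84 log units; beyond the scatter), and against phenyl the reading is a 1.2-fold higher number from compound 1 to compound 4 (0.09 log units; within the scatter), so in this series the hydroxy cancels the gain that methyl gave on the same ring. Nothing measured on these compounds explains this reversal.

On these data alone, whether a methoxy or an amine in place of the hydroxy would also raise the number remains open. As far as these compounds go, it is equally open whether hydroxy has the same effect on a ring without the methyl, or on one carrying fluoro.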